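The source may hold more compounds than are shown below. What is called first, only, known or untested is meant among the compounds shown, and "the series" means these compounds.

Compound 2, with the structure `CNC(=O)NCCCCCCn1c(C)nc(-c2ccccc2)c1-c1ccccc1`, carries a (methylcarbamoyl)amino group at the end of its six-carbon chain. In an assay on H4 cells for inhibition of Fatty-acid amide hydrolase 1 (Homo sapiens) (a lower number here means a stronger inhibitor, a higher number a weaker inhibitor), compound 2 gives > 10000 nM, which is a limit of the assay rather than a number, so its strength is known only to that extent (the limit of > 10000 nM in this assay, at which 1 of the 2 values shown sits). Compound 3, with the structure `Cc1nc(-c2ccccc2)c(-c2ccccc2)n1CCCCCCNC(=O)Oc1ccccc1`, differs from compound 2 by phenoxy in place of methylamino on a carbonyl carbon. For the measured compounds named here, the only measured step in this set, from compound 1 with the structure `CNC(=O)CCCCCCn1c(C)nc(-c2ccccc2)c1-c1ccccc1` and its value 1700 nM, is an at least 5.8-fold higher number from compound 1 to compound 2 (0.76 log units; beyond the scatter); it changes a different part of the chain end and does not cover the exchange made here. Going by the values given here, no measured step therefore speaks directly to this change, and the expectation rests on little. Compound 3 is estimated at 1000 nM, within a range from 100 nM to 10000 nM, which would mean an expected step of an at least 10-fold lower number from compound 2 to compound 3 (1.00 log units; beyond the scatter) in this assay.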

Compound 3, half-maximal inhibitory concentration: 5.3 nM
For compound 3 the middle estimate is 190-fold (2.28 log units) above the measured one; the whole stated range lies above it.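

In this assay, for the compounds shown here, putting phenoxy in place of methylamino on the carbonyl carbon gives an at least 1800-fold lower number from compound 2 to compound 3 (3.27 log units; beyond the scatter), so what sits on this carbonyl decides between a very weak and a very strong inhibitor, which the earlier compounds gave no sign of. Compound 2 carries a limit of the assay and not a number: the limit of > 10000 nM in this assay, at which 1 of the 3 values shown sits. The full exchange at the end of the chain, (phenoxycarbonyl)amino in place of methylcarbamoyl, gives a 320-fold lower number from compound 1 to compound 3 (2.51 log units; beyond the scatter), a large step that is a true number on both sides.

Phenoxy brings an oxygen and a ring in one change, so the compounds shown cannot tell which of the two goes with the gain. Methoxy, which keeps the oxygen without the ring, and phenylamino, which keeps the ring without the oxygen, would separate them on the same carbonyl carbon, and a shorter or longer chain would show how much the six-carbon length matters.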